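A thiophen-3-yl swap on the shared core

The source may hold more compounds than are shown below. What is called first, only, known or untested is meant among the compounds shown, and "the series" means these compounds.

In a functional assay on DU-145 cells (Homo sapiens) for inhibition, read by MTT assay, with a stated time of 48 h (a higher number here means a weaker inhibitor, a lower number a stronger inhibitor), compound 1 (`CCc1ccc(-c2nc3ccccn3c2Sc2ccccc2)cc1`) reads 84500 nM and compound 2 (`c1ccc(Sc2c(-c3ccccc3)nc3ccc(-c4ccccc4)cn23)cc1`) reads 71700 nM while compound 3 (`Clc1ccc(Sc2c(-c3ccccc3)nc3ccccn23)cc1`) reads 76700 nM with all three lying within the scatter of one another. Compound 1 therefore stands level with both. Compound 4 (`c1ccc(Sc2c(-c3ccsc3)nc3ccccn23)cc1`) differs from compound 1 at one place, on an aromatic carbon, where thiophen-3-yl stands in place of 4-ethylphenyl (thiophen-3-yl in place of 4-ethylphenyl on an aromatic carbon). Among the measured compounds shown here, no measured pair differing in one place is available to gauge such a change, so the expectation rests on these three close values. No step beyond the scatter is expected in this assay for this swap. The estimated change is a 1.2-fold lower number from compound 1 to compound 4 (0.07 log units; within the scatter) and no more. For compound 4 the expected value is 72000 nM with an estimated range from 35000 nM to 140000 nM as the likely span.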

Compound 4, half-maximal inhibitory concentration: 85900 nM
Compound 4: the middle estimate sits 1.2-fold (0.08 log units) below what was measured; measured number inside the range.
By their numbers in this assay, from the lowest: compounds 2, 3, 1 and 4 (each within the scatter of the next).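

In this assay, the swap gives the first step measured between compounds differing in one place, a 1.0-fold higher number from compound 1 to compound 4 (0.01 log units; within the scatter), which lies within the scatter. At this aromatic carbon, the five-membered thiophen-3-yl ring with its sulfur therefore reads level with the six-membered 4-ethylphenyl ring of carbon only. No measured evidence bears on the reason for this result.

From the compounds shown here alone, whether an amine or a carboxylic acid on the ring at this aromatic carbon would give a step beyond the scatter remains open. So does whether any group here separates the numbers in this assay at all.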